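This account rests on a few compounds, and the source may have more. Where it says the series, first, only, none or still open, it means among the compounds named here.

Measured compounds:
compound 1, `COc1ccc(Nc2ncnc3cc(OC)c(OCCCCC(=O)Nc4ccc(S(N)(=O)=O)cc4)cc23)cc1`; in a functional assay on A549 cells (Homo sapiens) for antiproliferative activity, read by MTT assay, with a stated time of 72 h (on this read-out lower numbers stand for stronger inhibition and higher numbers for weaker inhibition), compound 1 gives only a limit, > 40000 nM.
compound 2, `COc1ccc(Nc2ncnc3cc(OC)c(OCCCCC(=O)Nc4ccc(S(N)(=O)=O)cc4)cc23)cc1OC`; compound 2 likewise reaches only a limit, > 40000 nM.
compound 3, `COc1cc2ncnc(Nc3ccc(C(F)(F)F)cc3)c2cc1OCCCCC(=O)Nc1ccc(S(N)(=O)=O)cc1`; compound 3 gives 14800 nM.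

Compound 3 is therefore the only one of the three with a number; the other two sit at the limit (the limit of > 40000 nM in this assay, at which 2 of the 3 values shown sit). The step from compound 1 to compound 3 reads an at least 2.7-fold lower number from compound 1 to compound 3 (0.43 log units; beyond the scatter), and the step from compound 2 to compound 3 reads an at least 2.7-fold lower number from compound 2 to compound 3 (0.43 log units; beyond the scatter); both are read against a limit, so only a lower bound of their size is known.

Compound 4, `CCc1ccc(Nc2ncnc3cc(OC)c(OCCCCC(=O)Nc4ccc(S(N)(=O)=O)cc4)cc23)cc1`, has not yet been measured. It differs from compound 3 by ethyl in place of trifluoromethyl on an aromatic carbon. Within the data shown here, the two measured steps show only that trifluoromethyl gave a number where methoxy did not; ethyl is a new group for this position, and no measured step shows its effect. Compound 4 is therefore expected to fall somewhere between the limit and the value of compound 3, with a step of a 1.7-fold higher number from compound 3 to compound 4 (0.23 log units; within the scatter) expected, though the chance of a limit-only result is substantial. The estimate for compound 4 is 25000 nM, within 7000 nM to 60000 nM.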

Compound 4, half-maximal inhibitory concentration: 12100 nM
For compound 4 the middle estimate is 2.1-fold (0.32 log units) above the measured one; the measured number falls inside the stated range.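

In this assay, replacing trifluoromethyl with ethyl gives a 1.2-fold lower number from compound 3 to compound 4 (0.09 log units; within the scatter), so a group without fluorine also gives a readable number at this place on the ring. Methoxy is now the group that stands apart: ethyl in its place gives an at least 3.3-fold lower number from compound 1 to compound 4 (0.51 log units; beyond the scatter), and 4-ethylphenyl in place of 3,4-dimethoxyphenyl gives an at least 3.3-fold lower number from compound 2 to compound 4 (0.51 log units; beyond the scatter). Both of these steps give only a lower bound of their size, as compound 1 and compound 2 are read against a limit: the limit of > 40000 nM in this assay, at which 2 of the 4 values shown sit.

As far as these compounds go, the true size of those two steps stays open. So does whether an amine, a chlorine atom or a longer chain such as propyl at this place would also give a readable number, or would end at the limit as methoxy does.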